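This account rests on a few compounds, and the source may have more. Where it says the series, first, only, none or still open, it means among the compounds named here.

Measured compounds:
compound 1 `CC(C)c1c(OC2CCCCC2C)cc(Cc2ccc(Cl)cc2)[nH]c1=O`: 109000 nM
compound 2 `CC1CCCCC1Oc1cc(CCc2ccccc2)[nH]c(=O)c1I`: > 300000 nM

Among the compounds with values here, compound 1 `CC(C)c1c(OC2CCCCC2C)cc(Cc2ccc(Cl)cc2)[nH]c1=O` is measured in an ADME assay on TZM cells (Homo sapiens) for cytotoxicity (a lower number here means that less compound is tolerated, a higher number that more compound is tolerated), and gives 109000 nM; this is the only plain number in the set. Compound 2 `CC1CCCCC1Oc1cc(CCc2ccccc2)[nH]c(=O)c1I` reaches only the limit of the assay, which for compound 2 is > 300000 nM. What is shown for compound 2 therefore sits at the limit of > 300000 nM in this assay, at which 1 of the 2 values shown sits, and yields no number at all.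

Compound 3 `CC(C)c1c(OC2CCCCC2C)cc(CCc2ccccc2)[nH]c1=O` has not yet been measured in this assay. It differs from compound 1 in one place: benzyl in place of 4-chlorophenyl on a saturated chain carbon bound to an aromatic carbon. Within the data shown here, no step between two measured compounds is known here, so the size of this change cannot be read from a precedent. The step from compound 1 to compound 3 is expected to be small, if anything a shift toward more compound being tolerated, and is estimated as a 1.4-fold higher number from compound 1 to compound 3 (0.14 log units; within the scatter). For compound 3 the estimate in this assay is 150000 nM, with a range from 60000 nM to 300000 nM, and there is a fair chance that compound 3 will also only reach a limit.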

Compound 3, half-maximal cytotoxic concentration: 114000 nM
Compound 3: middle estimate off by 1.3-fold (0.12 log units), on the high side, and the stated range covers the measured number.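

In this assay, within the data shown here, the swap at the saturated chain carbon bound to an aromatic carbon can now be read for the first time: benzyl in place of 4-chlorophenyl gives a 1.0-fold higher number from compound 1 to compound 3 (0.02 log units; within the scatter), so this change, which can also be read as 4-chlorobenzyl to phenethyl, leaves the read-out within the usual scatter. Among these compounds, the second change, isopropyl in place of iodo on an aromatic carbon, gives an at least 2.6-fold lower number from compound 2 to compound 3 (0.42 log units; beyond the scatter), the only step here that lies beyond the scatter. That step is only a bound, not a full size, as compound 2 gives a limit and not a number: the limit of > 300000 nM in this assay, at which 1 of the 3 values shown sits.

As far as these compounds go, the true size of the step from iodo to isopropyl therefore stays open, and a single pair cannot show whether other groups at that aromatic carbon would behave like either of these two. From the compounds shown here alone, it also remains open whether a longer chain than phenethyl, or an amine on that chain, would move the number in this assay beyond the scatter.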